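The source may report more compounds than this note shows. Statements on the series, on what has been measured and on what is new or still open speak of the compounds shown alone.

Measured compounds:
compound 1, `COc1c(Cl)ccc2c1CCC2c1ncc[nH]1`
compound 2, `Cc1c(OCC2=NCCN2)ccc(Cl)c1NS(C)(=O)=O`
compound 3, `CCS(=O)(=O)Nc1cccc2c1CCC2c1ncc[nH]1`

In a functional assay on CHO cells for agonist activity at Alpha-1D adrenergic receptor (Homo sapiens), read by FLIPR and calcium flux (a higher number here means that more compound is needed for the effect, a lower number that less compound is needed), compound 1 gives > 10000 nM, which is a limit of the assay and not a number. In this assay compound 2 gives > 10000 nM, again a limit. In this assay compound 3 gives > 10000 nM, likewise a limit. Compound 3 therefore stands where every value shown stands: at the limit of > 10000 nM in this assay, at which 3 of the 3 values shown sit. Among the compounds with values here, no pair of measured compounds differs in one place, so no measured step is available, and the three values give no indication of where a real number would fall for any of them.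

Compound 4, `CNC(=O)c1cccc2c1CCC2c1ncc[nH]1`, is not yet measured in this assay. It differs from compound 3 in one place: methylcarbamoyl in place of (ethylsulfonyl)amino on an aromatic carbon. The core of compound 3 is kept unchanged.

Within the data shown here, the starting point is itself only a limit, and the series offers no measured step to set the size of the change. No step beyond the scatter is expected, a step that the limit leaves unreadable from compound 3 to compound 4. Compound 4 is expected to stay at or beyond the limit of this assay, with an estimate of 15000 nM within 3000 nM to 60000 nM, and a limit rather than a number is the more likely report.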

Compound 4, half-maximal effective concentration: > 10000 nM
Compound 4 ended at the assay's limit (the forecaster's own chance of this, stated with the estimate: 80%); the middle value lies beyond the limit too.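

In this assay compound 4 gives > 10000 nM, a limit of the assay and not a number. No step can be read between compound 3 and compound 4, so the exchange of (ethylsulfonyl)amino for methylcarbamoyl has no readable size. The series stands as follows: the limit of > 10000 nM in this assay, at which 4 of the 4 values shown sit.

The compounds shown leave open where any real value in this assay would fall, and which change on the shared core would bring one within range.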